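The source may report more compounds than this note shows. Statements on the series, on what has been measured and on what is new or still open speak of the compounds shown alone.

Measured compounds:
- compound 1 `Cc1c[nH]c(C)c1C(=O)O` gives 100000 nM
- compound 2 `Cc1cccc(-n2c(C)cc(C(=O)O)c2C)c1` gives 1500 nM

Both numbers come from an assay on cells for inhibition of Palmitoleoyl-protein carboxylesterase NOTUM variant C330S (Homo sapiens), read by fluorescence, with a stated time of 40 min; a higher number here means a weaker inhibitor, a lower number a stronger inhibitor. Compound 2 holds the lowest of the two values; its nearest neighbour is compound 1, whose value is far higher, a gap that lies well beyond the scatter. The two structures differ in more than one place, so no single step can be read from that pair; the pair only shows that the shared core carrying a substituted aryl ring on nitrogen gives the much lower number.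

The next compound, compound 3 `CCOc1cccc(-n2c(C)cc(C(=O)O)c2C)c1`, differs from compound 2 by one change: ethoxy in place of methyl on an aromatic carbon. Among the compounds with values here, no step of this kind has been measured, and the pair of compound 1 and compound 2 gives no guidance on it. The expectation is therefore a step of modest size in this assay, with a slight lean towards a lower number, though a change within the scatter is equally plausible; the estimated step is a 1.4-fold lower number from compound 2 to compound 3 (0.13 log units; within the scatter). Compound 3 is expected to give about 1100 nM, with a likely range from 300 nM to 4500 nM.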

Compound 3, half-maximal inhibitory concentration: 640 nM
The estimate for compound 3 lay 1.7-fold (0.24 log units) above the measured number, within the range that was stated.
By their numbers in this assay, from the lowest: compound 3; then compound 2; then compound 1.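

In this assay, the aromatic carbon meta to a large group responds to what is placed on it: ethoxy in place of methyl gives a 2.3-fold lower number from compound 2 to compound 3 (0.37 log units; beyond the scatter). Within the data shown here, this is the first change at a single place that can be read, since compound 1 and compound 2 differ in more than one place and could only point to the shared core carrying a substituted aryl ring on nitrogen. The entering group brings 3 heavy atoms where the leaving group has 1, and it adds 1 hydrogen-bond acceptor where the methyl has none, but no measurement here explains why the number falls.

Among these compounds, with only this one step, the effect of the added oxygen cannot be separated from that of the longer group, so methoxy, an ethyl chain and a propoxy chain at this carbon would each be needed to tell them apart. Also open, as far as these compounds go, is whether the trend continues or reverses with larger or different groups here, such as a longer alkoxy chain, an amine or a fluorine atom.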